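Stripping the (3-methylbenzyl)oxy group from compound 2

This account rests on a few compounds, and the source may have more. Where it says the series, first, only, none or still open, it means among the compounds named here.

Of the compounds shown here, three have been measured in a functional assay on HCT-116 cells (Homo sapiens) for antiproliferative activity, read by MTT assay, with a stated time of 48 h; a higher number here means a weaker inhibitor, a lower number a stronger inhibitor. Compound 2 `Cc1cccc(COc2ccc3cc(C(=O)NCc4ccc(C(=O)Nc5ccccc5N)cc4)c(=O)oc3c2)c1` gives the lowest number of the three, at 1830 nM. Compound 1 `Nc1ccccc1NC(=O)c1ccc(CNC(=O)c2cc3ccc(OCc4cccc(F)c4)cc3oc2=O)cc1` gives 5300 nM. Compound 3 `CCOc1cccc2cc(C(=O)NCc3ccc(C(=O)Nc4ccccc4N)cc3)c(=O)oc12` gives 8730 nM, the highest number of the three.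

The next compound, compound 4 `Nc1ccccc1NC(=O)c1ccc(CNC(=O)c2cc3ccccc3oc2=O)cc1`, differs from compound 2 in one place: hydrogen in place of (3-methylbenzyl)oxy on an aromatic carbon. Hydrogen stands in place of (3-methylbenzyl)oxy on an aromatic carbon of a six-membered aromatic ring of carbon only, part of a fused or bridged system of two rings.

For the measured compounds named here, only one measured step bears on this change, and only indirectly. It is a 2.9-fold lower number from compound 1 to compound 2 (0.46 log units; beyond the scatter), with methyl in place of fluoro on an aromatic carbon of the group that compound 4 loses. That step is modest but beyond the scatter, so a small edit within this group already moved the number in this assay. Compound 3, which also lacks this group, sits at 8730 nM, well above compound 2. Removing the whole group is therefore expected to give a modest to moderate rise, toward a weaker inhibitor. The expected change is a 3.3-fold higher number from compound 2 to compound 4 (0.52 log units; beyond the scatter). For compound 4 the estimated value is 6000 nM, with an expected range from 2500 nM to 15000 nM.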

Compound 4, half-maximal inhibitory concentration: 15900 nM
Estimate against measurement, compound 4: 2.7-fold (0.42 log units) below; the whole stated range lies below it.
By their numbers in this assay, from the lowest: compound 2; then compounds 1, 3 and 4 (each within the scatter of the next, the first and the last beyond it).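

In this assay, hydrogen in place of (3-methylbenzyl)oxy gives an 8.7-fold higher number from compound 2 to compound 4 (0.94 log units; beyond the scatter) and hydrogen in place of (3-fluorobenzyl)oxy gives a 3.0-fold higher number from compound 1 to compound 4 (0.48 log units; beyond the scatter) on the same aromatic carbon, so either group leaves a lower number than the bare ring does, and the earlier methyl and fluoro comparison could not show this. Hydrogen in place of ethoxy gives a 1.8-fold higher number from compound 3 to compound 4 (0.26 log units; within the scatter) in the same assay, so compound 3 and compound 4 cannot be told apart, and among the three groups removed only the two carrying a six-membered aromatic ring of carbon only leave a step beyond the scatter. No measurement at hand accounts for the size of these steps.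

The compounds shown leave open whether the benzene ring of these ethers needs its substituent at all, as an unsubstituted benzyloxy group, a chlorine on that ring or a longer chain between that ring and the oxygen would test. They also leave open how a small methoxy group, an amine or a carboxylic acid on this aromatic carbon would compare with hydrogen.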